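Series notes: extending the aryl alkyl chain, propyl to pentyl

The compounds below may be only part of what the source reports. "The series", "measured", "known", "first", "only" and "open" are said of these compounds alone.

Measured so far in a functional assay on CCRF-CEM cells (Homo sapiens) for antiproliferative activity, read by MTT assay, with a stated time of 96 h; on this read-out lower numbers stand for stronger inhibition and higher numbers for weaker inhibition:
- compound 1 `CCCc1ccc(N2C(=O)NC3(CSC4=C3C(=O)c3ncccc3C4=O)C2=O)cc1`: 1 nM
- compound 2 `O=C1NNC(=O)C2(CSC3=C2C(=O)c2ncccc2C3=O)N1`: 450 nM
- compound 3 `O=C1NN(c2ccc([N+](=O)[O-])cc2)C(=O)C2(CSC3=C2C(=O)c2ncccc2C3=O)N1`: 2 nM

Compound 1 sits at the low end of the numbers shown; compound 3 lies within the scatter of it, and compound 2 stands far above both. For the measured compounds named here, the only single-place step, a 230-fold lower number from compound 2 to compound 3 (2.35 log units; beyond the scatter), concerns the nitrogen substituent of the core and says nothing about the alkyl chain on that aryl group.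

Compound 4 `CCCCCc1ccc(N2C(=O)NC3(CSC4=C3C(=O)c3ncccc3C4=O)C2=O)cc1` differs from compound 1 by ethyl in place of hydrogen on a saturated chain carbon, three bonds along the chain from an aromatic carbon. Going by the values given here, no measured pair bears on this kind of change, so the expectation rests on compound 1 alone: a step of a 1.5-fold higher number from compound 1 to compound 4 (0.18 log units; within the scatter) that does not go beyond the scatter. The estimate for compound 4 in this assay is 1.5 nM, with a range from 0.5 nM to 5 nM.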

Compound 4, half-maximal inhibitory concentration: 250 nM
For compound 4 the middle estimate is 170-fold (2.22 log units) below the measured one; measured number above the stated range.
By their numbers in this assay, from the lowest: compounds 1 and 3 (each within the scatter of the next); then compounds 4 and 2 (each within the scatter of the next).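

In this assay the aryl alkyl chain turns out not to be a free position: ethyl in place of hydrogen on a saturated chain carbon, three bonds along the chain from an aromatic carbon, costs a large step (a 250-fold higher number from compound 1 to compound 4 (2.40 log units; beyond the scatter)). Until now, a large step had been seen only at the nitrogen substituent; this one comes from 2 added carbons at the chain end.

Open, going by these compounds, is whether a butyl chain stays close to compound 1 or already falls with compound 4, and whether a methyl or ethyl chain holds the low number. Nothing measured here accounts for the step.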